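Methoxy for fluoro on a bis-benzylidene cyclohexanone

This account rests on a few compounds, and the source may have more. Where it says the series, first, only, none or still open, it means among the compounds named here.

Of the compounds shown here, three have been measured in a functional assay on MOLT-4 cells (Homo sapiens) for cytotoxicity, with a stated time of 72 h; a higher number here means a weaker inhibitor, a lower number a stronger inhibitor. Compound 1 `O=C1CCCC/C1=C\c1cccc([N+](=O)[O-])c1` gives 8280 nM, and compound 2 `O=C1CCCC/C1=C\c1ccccc1[N+](=O)[O-]` gives 33300 nM. Compound 3 `O=C1/C(=C/c2ccc(F)cc2)CCC/C1=C\c1ccc([N+](=O)[O-])cc1` carries a second benzylidene arm, a 4-fluorophenyl group, on the shared core and gives 17100 nM in this assay . Among the three numbers, compound 3 stands second highest; its value and that of compound 2 lie within the usual scatter of each other, while compound 1 sits beyond the scatter at the lower end.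

Compound 4 `COc1ccc(/C=C2\CCC/C(=C\c3ccc([N+](=O)[O-])cc3)C2=O)cc1` differs from compound 3 in one place: methoxy in place of fluoro on an aromatic carbon. Going by the values given here, no measured pair shows this exchange, so its effect in this assay is not known from the present data. With compound 3 at 17100 nM as the only anchor, a step of a 1.1-fold lower number from compound 3 to compound 4 (0.06 log units; within the scatter) is expected, that is, no change beyond the scatter in either direction. Compound 4 is therefore estimated to give 15000 nM, within a range from 5000 nM to 45000 nM.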

Compound 4, half-maximal inhibitory concentration in the MOLT-4 assay: 300000 nM
For compound 4 the middle estimate is 20-fold (1.30 log units) below the measured one; measured number above the stated range.
By their numbers in the MOLT-4 assay, from the lowest: compound 1; then compounds 3 and 2 (each within the scatter of the next); then compound 4.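

At this place, on an aromatic carbon para to a large group, the change from 4-fluorophenyl to 4-methoxyphenyl is far from neutral: in the MOLT-4 assay compound 3 gives 17100 nM and compound 4 gives 300000 nM, so methoxy in place of fluoro gives an 18-fold higher number from compound 3 to compound 4 (1.24 log units; beyond the scatter), the first single-place step measured in this series. In a physicochemical assay for lipophilicity (a higher number here means a more lipophilic compound, a lower number a more polar compound), compound 3 gives 5.08 and compound 4 gives 5.08, so the same exchange gives no change at the digits printed from compound 3 to compound 4 (within the scatter), and the large step in the cell assay comes with no difference in the partition coefficient. Nothing available bears on why this exchange has so large an effect.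

The compounds shown leave open whether another group at this place, such as a hydroxyl, an amine or a chlorine, would stay near compound 3 or fall with compound 4. They also leave open whether the same exchange would give a step of this size on a compound with a different second arm.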